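A few compounds are considered here, and "the series" means these few. Any claim that something is new, unique, unknown or untested is made for them only; others in the source may bear on it.

Compound 1 `CCOC(=O)[C@@H]1CCCN(S(=O)(=O)c2ccc(S(=O)(=O)N(CC)CC)cn2)C1`: 1400 nM
Compound 2 `CCC(CC)S(=O)(=O)c1ccc(S(=O)(=O)N2CCC[C@@H](C(=O)N3CCN(c4nc(C(C)C)no4)CC3)C2)cc1`: 120 nM

Both compounds were tested in a functional assay on BXPC-3 cells (Homo sapiens) for inhibition, read by MTT assay, with a stated time of 7 days; on this read-out lower numbers stand for stronger inhibition and higher numbers for weaker inhibition. Compound 2 stands at the lower of the two numbers, and on this read-out a lower number means stronger inhibition; compound 1 lies well beyond the usual scatter from it. Compound 1 and compound 2 differ in more than one place. The gap between them cannot be pinned on any single change.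

Compound 3 `CCN(CC)C(=O)c1ccc(S(=O)(=O)N2CCC[C@@H](C(=O)N3CCN(c4nc(C(C)C)no4)CC3)C2)cc1` has not yet been measured. It differs from compound 2 in one place: diethylcarbamoyl in place of (pentan-3-yl)sulfonyl on an aromatic carbon. For the measured compounds named here, no measured pair shows this particular change, so its effect is not known from the data here. The expectation is a modest step toward a higher number, a 2.5-fold higher number from compound 2 to compound 3 (0.40 log units; beyond the scatter), somewhat weaker inhibition than compound 2 but still far from compound 1. Compound 3 is expected to give 300 nM, within 100 nM to 1000 nM.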

Compound 3, half-maximal inhibitory concentration: 1400 nM
Compound 3: middle estimate off by 4.7-fold (0.67 log units), on the low side, outside the stated range (above it).
By their numbers in this assay, from the lowest: compound 2; then compounds 1 and 3 (each within the scatter of the next).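

In this assay, for the compounds shown here, placing diethylcarbamoyl instead of (pentan-3-yl)sulfonyl on the aromatic carbon para to a large group gives a 12-fold higher number from compound 2 to compound 3 (1.07 log units; beyond the scatter), the first change in a single place that can be read here. This shows that inhibition is sensitive to the group at this position, even with the rest of the molecule unchanged. The size of the step is notable since neither group has a ring, a hydrogen-bond donor or a net charge, yet nothing here explains the loss.

A single pair cannot show whether the sulfonyl link or the branched pentan-3-yl chain matters more for the lower number of compound 2. A methylsulfonyl group, or a simple carboxylic acid, at the same position would leave that question open too until its value is known.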